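Swapping Chloro for Fluoro on the Benzyl Ring

This account rests on a few compounds, and the source may have more. Where it says the series, first, only, none or still open, it means among the compounds named here.

Compound 1 `O=C(/C=C/c1cccn1Cc1ccccc1)CC(=O)C(=O)O`: 1500 nM
Compound 2 `O=C(/C=C/c1cccn1Cc1ccc(Cl)cc1)CC(=O)C(=O)O`: > 95000 nM (a limit)

In a functional assay on MT4 cells (Homo sapiens) (a lower number here means that less compound is needed, a higher number that more compound is needed for the effect), compound 1 gives 1500 nM. Compound 2 gives > 95000 nM, which is a limit of the assay and not a number.

Compound 3 `O=C(/C=C/c1cccn1Cc1ccc(F)cc1)CC(=O)C(=O)O` differs from compound 2 in one place, with fluoro in place of chloro on an aromatic carbon. For the measured compounds named here, one measured step bears on this change, chloro in place of hydrogen on an aromatic carbon, and it is large and beyond the scatter: an at least 63-fold higher number from compound 1 to compound 2 (1.80 log units; beyond the scatter). Compound 3 gives up that chloro, so a large step towards a lower number is expected. Going by the values given here, no measured step yet shows what fluoro does at this place, so the expectation is uncertain. Estimated from this, the change is an at least 15-fold lower number from compound 2 to compound 3 (1.19 log units; beyond the scatter). Compound 3 is estimated at 6000 nM, with an expected range of 1000 nM to 60000 nM.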

Compound 3, half-maximal effective concentration: 11000 nM
The estimate for compound 3 lay 1.8-fold (0.26 log units) below the measured number; measured number inside the range.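

In this assay, the para position of the benzyl ring responds not just to whether a halogen is present but to which one: fluoro in place of chloro gives an at least 8.6-fold lower number from compound 2 to compound 3 (0.93 log units; beyond the scatter). Fluoro still does not match the unsubstituted ring, as fluoro in place of hydrogen gives a 7.3-fold higher number from compound 1 to compound 3 (0.87 log units; beyond the scatter), so both halogens shown here raise the number relative to hydrogen, chloro by more. Compound 2 stands at a limit of the assay and not at a number, so the step from chloro to fluoro has only a lower bound: the limit of > 95000 nM in this assay, at which 1 of the 3 values shown sits.

As far as these compounds go, whether a methyl or methoxy group at this place would also raise the number, or an amine would leave it close to compound 1, stays open. The compounds shown also do not tell why the two halogens differ.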